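A few compounds are considered here, and "the series" means these few. Any claim that something is new, unique, unknown or untested is made for them only; others in the source may bear on it.

Measured in a functional assay on HCT-116 cells (Homo sapiens) for antiproliferative activity, read by MTT assay, with a stated time of 72 h; a lower number here means a stronger inhibitor, a higher number a weaker inhibitor:
- compound 1 `COc1ncc(-c2ccc3c(c2)N(c2ccc(C)cc2)C(=O)CO3)cc1NS(=O)(=O)c1ccc(F)cc1`: 22700 nM
- compound 2 `O=C1COc2ccc(-c3cnc(Cl)c(NS(=O)(=O)c4ccc(F)cc4)c3)cc2N1C1CCCCC1`: > 40000 nM (a limit of the assay, not a number)
- compound 3 `COc1ccc(N2C(=O)COc3ccc(-c4ccc(O)cc4)cc32)cc1`: 26100 nM

Only two of these results are true numbers. Compound 1 gives 22700 nM and compound 3 gives 26100 nM, which lie within the scatter of each other, so neither can be ranked ahead.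

The next compound is compound 4 `COc1ncc(-c2ccc3c(c2)NC(=O)CO3)cc1NS(=O)(=O)c1ccc(F)cc1`, which keeps the core of compound 1 but has hydrogen in place of 4-methylphenyl on an amide-type nitrogen in a ring.

Among the measured compounds shown here, no measured pair isolates this change, and no measured compound has hydrogen at this place, so the size of the step is poorly constrained. Compound 1 at 22700 nM is already a weak inhibitor, so a moderate move toward a lower number is expected, though a result within the scatter would not surprise. The expected change is a 2.3-fold lower number from compound 1 to compound 4 (0.36 log units; beyond the scatter). For compound 4 the estimated value is 10000 nM, with an expected range from 1500 nM to 40000 nM.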

Compound 4, half-maximal inhibitory concentration: 24900 nM
Estimate against measurement, compound 4: 2.5-fold (0.40 log units) below; the measured number falls inside the stated range.
By their numbers in this assay, from the lowest: compounds 1, 4 and 3 (each within the scatter of the next). At a limit, above all of these: compound 2.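

Hydrogen in place of 4-methylphenyl on an amide-type nitrogen in a ring gives a 1.1-fold higher number from compound 1 to compound 4 (0.04 log units; within the scatter) in this assay, the first measured pair that isolates this place. Among the compounds shown here, the whole 4-methylphenyl group can therefore leave this nitrogen with no readable change in the number, and the earlier compounds could not show this. Nothing given here points to a cause for so flat a step.

Whether any group on this nitrogen moves the number stays open, since a methyl, an aminoethyl chain or a chain ending in a carboxylic acid are not among the compounds shown. For the compounds shown here, compound 2 holds only a limit of the assay and differs from compound 1 in more than one place, so no step to it can be read.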